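From 3-chlorobenzyl to benzyl: a small expected step

The source may hold more compounds than are shown below. What is called first, only, known or untested is meant among the compounds shown, and "the series" means these compounds.

In an ADME assay on cells (Astrocyte, Homo sapiens) for cytotoxicity, read by WST assay, with a stated time of 72 h (a lower number here means a stronger inhibitor, a higher number a weaker inhibitor), compound 3 `O=C(Nc1ccc(C(F)(F)F)cc1)Nc1cc2ncncc2cc1OCc1cccc(Cl)c1` gives 8800 nM. Compound 1 `O=C(Nc1ccc(C(F)(F)F)cc1)Nc1cc2ncncc2cc1OCc1cccc(F)c1` gives 8900 nM, which places it level with compound 3. Compound 2 `O=C(Nc1ccccc1F)Nc1cc2ncncc2cc1OCc1ccccc1` reads > 10000 nM, and this is a limit of the assay, not a number.

Compound 4 `O=C(Nc1ccc(C(F)(F)F)cc1)Nc1cc2ncncc2cc1OCc1ccccc1` replaces the 3-chlorobenzyl group of compound 3 with benzyl, putting hydrogen in place of chloro on an aromatic carbon. Among the measured compounds shown here, one measured step bears on this position: chloro in place of fluoro, which amounts to a 1.0-fold lower number from compound 1 to compound 3 (0.00 log units; within the scatter). That step exchanges one halogen for another and does not remove the halogen, so it is only partial guidance. Compound 2 also carries benzyloxy, but it differs elsewhere as well, so it isolates nothing. On the evidence of compound 1 and compound 3, no shift beyond the scatter is expected in this assay. The expected change is a 1.1-fold higher number from compound 3 to compound 4 (0.03 log units; within the scatter). For compound 4 the estimate is 9500 nM, with an expected range of 6000 nM to 15000 nM.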

Compound 4, half-maximal inhibitory concentration: 9200 nM
Beside the measured number, compound 4's estimate is 1.0-fold (0.01 log units) above it; the measured number falls inside the stated range.
By their numbers in this assay, from the lowest: compounds 3, 1 and 4 (each within the scatter of the next). At a limit, above all of these: compound 2.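

In this assay the halogen on the benzyl group is now removed, not only exchanged: hydrogen in place of chloro gives a 1.0-fold higher number from compound 3 to compound 4 (0.02 log units; within the scatter) and hydrogen in place of fluoro gives a 1.0-fold higher number from compound 1 to compound 4 (0.01 log units; within the scatter) on the same aromatic carbon. Across compound 1, compound 3 and compound 4, then, fluoro, chloro and hydrogen at this position show no shift beyond the scatter. On the other side of the molecule, 4-(trifluoromethyl)phenyl in place of 2-fluorophenyl gives an at least 1.0-fold lower number from compound 2 to compound 4 (0.03 log units; that floor lies within the scatter) as a floor only, and that step rests on a limit of the assay: (the limit of > 10000 nM in this assay, at which 1 of the 4 values shown sits).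

From the compounds shown here alone, whether an amine, a carboxylic acid or a methoxy group on this aromatic carbon would move the number remains open. So does the true size of the step between 2-fluorophenyl and 4-(trifluoromethyl)phenyl.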